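A few compounds are considered here, and "the series" means these few. Any claim that something is new, unique, unknown or untested is made for them only; others in the source may bear on it.

In a functional assay on A549 cells (Homo sapiens) for antiproliferative activity, read by MTT assay (on this read-out lower numbers stand for stronger inhibition and higher numbers for weaker inhibition), compound 1 `COc1cc2c(Oc3ccc(NC(=O)Nc4cccc(C)c4)cc3)ccnc2cc1OCCCCCCC(=O)NO` gives 2010 nM, compound 2 `COc1cc2c(Oc3ccc(NC(=O)Nc4ccc(C)cc4C)cc3)ccnc2cc1OCCCCCCC(=O)NO` gives 5490 nM and compound 3 `COc1cc2c(Oc3ccc(NC(=O)N/N=C/c4ccc(F)cc4)cc3)ccnc2cc1OCCCCCCC(=O)NO` gives 4920 nM. Compound 3 is therefore level with compound 2, with a 1.1-fold lower number from compound 2 to compound 3 (0.05 log units; within the scatter), and sits on the weaker side of compound 1, with a 2.4-fold higher number from compound 1 to compound 3 (0.39 log units; beyond the scatter). Compound 4 `COc1cc2c(Oc3ccc(NC(=O)NNC(=O)c4ccccc4F)cc3)ccnc2cc1OCCCCCCC(=O)NO` differs from compound 3 on the amide-type nitrogen: a group of 10 heavy atoms (7 carbon, 1 nitrogen, 1 oxygen, 1 fluorine; one six-membered aromatic ring of carbon only) in place of a group of 9 heavy atoms (7 carbon, 1 nitrogen, 1 fluorine; one six-membered aromatic ring of carbon only), on an amide-type nitrogen. For the measured compounds named here, no measured step isolates this change. The nearest evidence is that replacing the group on this nitrogen in compound 1 gave only a modest shift, a 2.7-fold higher number from compound 1 to compound 2 (0.44 log units; beyond the scatter), while compound 2 and compound 3 stay level despite different groups. The expected step is a 1.2-fold lower number from compound 3 to compound 4 (0.09 log units; within the scatter), which would not exceed the scatter. For compound 4 the estimated value is 4000 nM, with an expected range of 1700 nM to 9500 nM.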

Compound 4, half-maximal inhibitory concentration: 2420 nM
The estimate for compound 4 lay 1.7-fold (0.22 log units) above the measured number; the measured number falls inside the stated range.
By their numbers in this assay, from the lowest: compounds 1 and 4 (each within the scatter of the next); then compounds 3 and 2 (each within the scatter of the next).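

On the amide-type nitrogen, ((2-fluorophenyl)carbonyl)amino is the first group shown in place of 3-methylphenyl that stays level with compound 1 in this assay (a 1.2-fold higher number from compound 1 to compound 4 (0.08 log units; within the scatter)). The same group reads apart from the other two replacements (a 2.0-fold lower number from compound 3 to compound 4 (0.31 log units; beyond the scatter); a 2.3-fold lower number from compound 2 to compound 4 (0.36 log units; beyond the scatter)), so this position does not treat all replacements alike. No measurement on hand accounts for these steps.

The compounds shown leave open whether the carbonyl or the fluorine of the entering group carries the step. From the compounds shown here alone, how an aminophenyl group or a carboxylic acid on this nitrogen would read also remains open.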